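Swapping cyclohexyl for benzyl on a shared core

The source may report more compounds than this note shows. Statements on the series, on what has been measured and on what is new or still open speak of the compounds shown alone.

Compound 1 `c1ccc2c(-c3cn4ccnc4c(-c4ccc5ncn(C6CCCCC6)c5c4)n3)cccc2c1` and compound 2 `Fc1ccc(-c2cn3ccnc3c(-c3ccc4ncn(C5CCCCC5)c4c3)n2)cc1` share the same core and differ in a single aromatic group. In a functional assay on NCI-H322M cells (Homo sapiens) for inhibition, read by sulforhodamine B assay, with a stated time of 48 h, tested at 10 uM (on this read-out higher numbers stand for more inhibition at the one concentration tested (going by the name of the read-out) and lower numbers for less inhibition), compound 1 gives 4.74%, and compound 2 gives 0.01%. The step of a number 4.7 percentage points lower from compound 1 to compound 2 (within the scatter) shows that exchanging naphthalen-1-yl for 4-fluorophenyl made no difference beyond the scatter. Of the two numbers shown, that of compound 1 is the higher, yet the gap lies within the scatter, so the two compounds cannot be ranked. Compound 3 `c1ccc(Cn2cnc3ccc(-c4nc(-c5cccc6ccccc56)cn5ccnc45)cc32)cc1` keeps the naphthalen-1-yl group of compound 1 and alters a different spot: benzyl in place of cyclohexyl on an aromatic nitrogen. Among the measured compounds shown here, no measured step touches this position, so nothing bears on it directly; the only step seen, from compound 1 to compound 2, stayed within the scatter, and both measured values sit near zero. For compound 3 the expected step is a number 0.3 percentage points higher from compound 1 to compound 3 (within the scatter), nothing beyond the scatter. Compound 3 is therefore estimated at 5%, within a range from -8% to 22%.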

Compound 3, a percentage reported as inhibition, at one concentration (the size of the read-out at that concentration, not a potency): 1.34%
For compound 3 the middle estimate is 3.7 percentage points above the measured one; the range from low to high includes it.
By their numbers in this assay, from the lowest: compounds 2, 3 and 1 (each within the scatter of the next).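

Among the compounds shown here, this is the first measured step at this position, the aromatic nitrogen of the five-membered ring: in this assay, benzyl in place of cyclohexyl gives a number 3.4 percentage points lower from compound 1 to compound 3 (within the scatter). At this nitrogen, then, the non-aromatic ring of cyclohexyl and the aromatic ring of benzyl cannot be told apart, and compounds 1, 2 and 3 cannot be ranked against one another. No available evidence offers an explanation for this result.

As far as these compounds go, whether a different kind of group on this nitrogen, such as a chain ending in an amine or a carboxylic acid, would change the number remains open. The compounds shown also leave open whether any change at this position could raise inhibition clearly beyond the scatter, since all three numbers stay close to zero.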